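The source may report more compounds than this note shows. Statements on the series, on what has been measured and on what is new or still open speak of the compounds shown alone.

Working notes on the series in a functional assay on MCF7 cells (Homo sapiens) for cytotoxicity, read by MTT assay, with a stated time of 72 h; a lower number here means a stronger inhibitor, a higher number a weaker inhibitor. Compound 1 `CSc1nc(Br)c(C(=O)c2ccccc2)s1` gives 67000 nM, compound 2 `O=C(c1ccccc1)c1sc(N2CCCC2)nc1Br` gives 69000 nM, and compound 3 `O=C(c1ccccc1)c1sc(N2CCCCC2)nc1Cl` gives 56000 nM. Compound 3 therefore stands within the scatter of both others. The next change leads to compound 4 `O=C(c1ccccc1)c1sc(N2CCCCC2)nc1Br`: bromo in place of chloro on an aromatic carbon. For the measured compounds named here, no measured step makes this exchange. Going by the values given here, the only measured step, a 1.0-fold higher number from compound 1 to compound 2 (0.01 log units; within the scatter), puts pyrrolidin-1-yl in place of methylsulfanyl and stays within the scatter. On that limited evidence, no change beyond the scatter is expected in this assay. The expected step is a 1.1-fold higher number from compound 3 to compound 4 (0.03 log units; within the scatter). The estimate for compound 4 is 60000 nM, with an expected range from 35000 nM to 100000 nM.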

Compound 4, half-maximal inhibitory concentration: 35000 nM
Compound 4: middle estimate off by 1.7-fold (0.23 log units), on the high side; the measured number falls inside the stated range.
By their numbers in this assay, from the lowest: compounds 4, 3, 1 and 2 (each within the scatter of the next).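

On the aromatic carbon next to the ring nitrogen, a 1.6-fold lower number from compound 3 to compound 4 (0.20 log units; within the scatter) in this assay comes with bromo in place of chloro, so this exchange now has a measured size, and it lies within the scatter. With bromo held, piperidin-1-yl in place of pyrrolidin-1-yl gives a 2.0-fold lower number from compound 2 to compound 4 (0.29 log units; within the scatter) and piperidin-1-yl in place of methylsulfanyl gives a 1.9-fold lower number from compound 1 to compound 4 (0.28 log units; within the scatter), both also within the scatter. No measurement shown offers an explanation for these numbers.

Going by these compounds, whether iodo or a hydrogen at this position, or a primary amine or a carboxylic acid in place of piperidin-1-yl, would move the number beyond the scatter remains open.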